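Benzylselanyl in place of methylsulfanyl on the shared core

A few compounds are considered here, and "the series" means these few. Any claim that something is new, unique, unknown or untested is made for them only; others in the source may bear on it.

Going by the values given here, compound 2 `CS/C(=N\C(=O)c1cc2ccccc2s1)NC(=O)c1cc2ccccc2s1` holds the higher of the two numbers so far in a functional assay on HepG2 cells (Homo sapiens) for cytotoxicity, read by MTT assay, with a stated time of 72 h (on this read-out higher numbers stand for lower toxicity in this test and lower numbers for higher toxicity in this test), giving 75800 nM, while compound 1 `C[Se]/C(=N\C(=O)c1cc2ccccc2s1)NC(=O)c1cc2ccccc2s1`, which differs only at the substituent on the carbon with a double bond to nitrogen, gives 73300 nM; the change a 1.0-fold higher number from compound 1 to compound 2 (0.01 log units; within the scatter) lies within the scatter. Compound 3 `O=C(/N=C(/NC(=O)c1cc2ccccc2s1)[Se]Cc1ccccc1)c1cc2ccccc2s1` carries a group of 8 heavy atoms (7 carbon, 1 selenium; one six-membered aromatic ring of carbon only) in place of a group of 2 heavy atoms (1 carbon, 1 sulfur; no ring), on a carbon with a double bond to nitrogen. Among the compounds with values here, of the measured steps only the exchange of sulfur for selenium from compound 1 to compound 2 bears on this change, and it was flat; no measured step covers the replacement of a methyl by the larger group that enters. The expected step of a 1.4-fold lower number from compound 2 to compound 3 (0.14 log units; within the scatter) is therefore small, with no confident direction beyond the scatter. Compound 3 is estimated at 55000 nM, within a range from 15000 nM to 160000 nM.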

Compound 3, concentration lethal to 50% of the cells: 77000 nM
Estimate against measurement, compound 3: 1.4-fold (0.15 log units) below, and the stated range covers the measured number.
By their numbers in this assay, from the lowest: compounds 1, 2 and 3 (each within the scatter of the next).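

In this assay, putting the group of 8 heavy atoms, with its one six-membered aromatic ring of carbon only, in place of methylsulfanyl on the carbon with a double bond to nitrogen gives a 1.0-fold higher number from compound 2 to compound 3 (0.01 log units; within the scatter). Phenyl in place of hydrogen on a saturated chain carbon bound to a selenium atom gives a 1.1-fold higher number from compound 1 to compound 3 (0.02 log units; within the scatter). Going by these compounds alone, this position had so far been probed only by the exchange of sulfur for selenium, and it now also takes a group bearing an aromatic ring with no step beyond the scatter in this test. Nothing available here accounts for this flat result.

As far as these compounds go, whether an amine or a carboxylic acid at this carbon, or a longer chain on the selenium, would give a step beyond the scatter remains open. So does how benzylsulfanyl would compare with the selenium group of compound 3.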